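This account rests on a few compounds, and the source may have more. Where it says the series, first, only, none or still open, it means among the compounds named here.

Three compounds share one core and were tested in an assay (strain Holtzman-Sprague-Dawley) for inhibition of 3-hydroxy-3-methylglutaryl-coenzyme A reductase (Rattus norvegicus), with a stated time of 30 min; on this read-out higher numbers stand for weaker inhibition and lower numbers for stronger inhibition. Compound 1 `O=C1C[C@H](O)C[C@@H](/C=C/c2cnc3c(F)c(F)c(F)cc3c2Sc2ccc(F)cc2)O1` gives 7930 nM, the lowest number of the three. Compound 2 `CC(C)c1ccc(Sc2ccc3c(Sc4ccc(C(C)C)cc4)c(/C=C/[C@@H]4C[C@@H](O)CC(=O)O4)cnc3c2)cc1` gives 15800 nM, which lies within the scatter of compound 1, so no order between these two can be read. Compound 3 `O=C1C[C@H](O)C[C@@H](/C=C/c2cnc3cc(Sc4ccccc4)c(Sc4ccccc4)cc3c2Sc2ccccc2)O1` gives 32600 nM, a number that stands beyond the scatter above compound 1.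

Compound 4 `CC(C)c1ccc(Sc2c(/C=C/[C@@H]3C[C@@H](O)CC(=O)O3)cnc3c(F)c(F)c(F)cc23)cc1` has not yet been measured. Relative to compound 1 it carries isopropyl in place of fluoro on an aromatic carbon. Within the data shown here, no measured pair shows this particular change. The step from compound 1 to compound 4 is expected to be small, a 1.3-fold higher number from compound 1 to compound 4 (0.10 log units; within the scatter), and not clearly beyond the scatter in either direction. Compound 4 is therefore estimated at 10000 nM, within a range from 3000 nM to 35000 nM.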

Compound 4, half-maximal inhibitory concentration: 3210 nM
The estimate for compound 4 lay 3.1-fold (0.49 log units) above the measured number; the measured number falls inside the stated range.
By their numbers in this assay, from the lowest: compound 4; then compounds 1 and 2 (each within the scatter of the next); then compound 3.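

In this assay, replacing 4-fluorophenyl with 4-isopropylphenyl on the sulfanyl group gives a 2.5-fold lower number from compound 1 to compound 4 (0.39 log units; beyond the scatter), so isopropyl at this place goes with stronger inhibition than fluoro. Among these compounds, the earlier compounds offered no step with a single difference, so this is the first reading of any one position. Nothing given here accounts for this step.

From the compounds shown here alone, whether a methyl, a tert-butyl or an amine at this place would give a lower number remains open. So does whether the isopropyl step holds on the core of compound 2.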